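The source may report more compounds than this note shows. Statements on the series, on what has been measured and on what is new or still open speak of the compounds shown alone.

Measured compounds:
Compound 1, `COc1cc(-c2nc(C(c3ccc(F)cc3)c3ccc(F)cc3)sc2CC(=O)O)ccn1`, gives 60% in an in vitro functional assay on HEK285-7 cells for antagonist activity at prostaglandin D2 receptor 2 (Homo sapiens), read by BRET and beta-arrestin recruitment; a lower number here means a smaller maximal response, a higher number a larger maximal response.
Compound 2, `O=C(O)Cc1sc(C(c2ccc(F)cc2)c2ccc(F)cc2)nc1-c1ccc(Cl)cc1`, gives 80%.
Compound 3, `Nc1cc(-c2nc(C(c3ccc(F)cc3)c3ccc(F)cc3)sc2CC(=O)O)cc(F)n1`, gives 30%.

Among these three numbers compound 3 stands lowest: the step of a number 30 percentage points lower from compound 1 to compound 3 (beyond the scatter) and the step of a number 50 percentage points lower from compound 2 to compound 3 (beyond the scatter) both lie beyond the scatter, so its maximal response is the smallest of the set. Compound 4, `O=C(O)Cc1sc(C(c2ccc(F)cc2)c2ccc(F)cc2)nc1-c1cn[nH]c1`, shares the core of compound 3 and differs in one place: 1H-pyrazol-4-yl in place of 2-amino-6-fluoropyridin-4-yl on an aromatic carbon. The measured steps that bear on this change are those that exchange the aromatic group at the same place: a number 20 percentage points higher from compound 1 to compound 2 (beyond the scatter), a number 30 percentage points lower from compound 1 to compound 3 (beyond the scatter) and a number 50 percentage points lower from compound 2 to compound 3 (beyond the scatter). They show that this position shifts the maximal response by modest to large amounts in either direction, with the 2-amino-6-fluoropyridin-4-yl group giving the smallest response of the three. Among the compounds with values here, no measured compound carries the 1H-pyrazol-4-yl group, so the size of the move is uncertain. The step from compound 3 is nonetheless expected to run upward, a number 20 percentage points higher from compound 3 to compound 4 (beyond the scatter), toward the middle of the measured range. Compound 4 is therefore estimated at 50%, within a range of 25% to 75%.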

Compound 4, largest response reached (reported as efficacy), in percent of the reference or control that the assay uses: 80%
The estimate for compound 4 lay 30 percentage points below the measured number; measured number above the stated range.
By their numbers in this assay, from the lowest: compound 3; then compound 1; then compounds 2 and 4 (each within the scatter of the next).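

In this assay, exchanging the 2-amino-6-fluoropyridin-4-yl group for 1H-pyrazol-4-yl gives a number 50 percentage points higher from compound 3 to compound 4 (beyond the scatter), and exchanging the 2-methoxypyridin-4-yl group for it gives a number 20 percentage points higher from compound 1 to compound 4 (beyond the scatter), while exchanging 4-chlorophenyl for it gives no change at the digits printed from compound 2 to compound 4 (within the scatter). This place therefore tolerates a five-membered aromatic ring with 2 hetero atoms without any loss from the top of the measured range, and the 1 hydrogen-bond donor counted on both the leaving and the entering group does not separate compound 3 from compound 4. Nothing available here explains these shifts.

The compounds shown leave open whether the response of compound 4 depends on the hydrogen on the pyrazole nitrogen, which a 1-methyl-1H-pyrazol-4-yl group would test. They also leave open whether an unsubstituted pyridin-4-yl group would sit with compound 2 and compound 4 or with compound 1 and compound 3.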